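The source may report more compounds than this note shows. Statements on the series, on what has been measured and on what is new or still open speak of the compounds shown alone.

Measured in a functional assay on A549 cells (Homo sapiens) for inhibition, read by sulforhodamine B assay, with a stated time of 48 h; on this read-out lower numbers stand for stronger inhibition of growth and higher numbers for weaker inhibition of growth:

- compound 1 (`COc1ccc(/C=C/C(=O)C(=Cc2cc(OC)c(OC)c(OC)c2)C(=O)/C=C/c2ccc(OC)c(OC)c2)cc1OC`) gives 230 nM
- compound 2 (`COc1ccc(/C=C/C(=O)C(=Cc2ccc(F)cc2)C(=O)/C=C/c2ccc(OC)c(OC)c2)cc1OC`) gives 550 nM
- compound 3 (`CCc1ccc(C=C(C(=O)/C=C/c2ccc(OC)c(OC)c2)C(=O)/C=C/c2ccc(OC)c(OC)c2)cc1`) gives 630 nM

Compound 3 stands level with compound 2 within the usual scatter (a 1.1-fold higher number from compound 2 to compound 3 (0.06 log units; within the scatter)), and the two sit together at the weak end of this small set. Only compound 1 is clearly separated from compound 3 (a 2.7-fold higher number from compound 1 to compound 3 (0.44 log units; beyond the scatter)).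

The next compound, compound 4 (`COc1ccc(C=C(C(=O)/C=C/c2ccc(OC)c(OC)c2)C(=O)/C=C/c2ccc(OC)c(OC)c2)c(OC)c1`), changes the same aryl group: 2,4-dimethoxyphenyl in place of 4-ethylphenyl on a double-bonded chain carbon bound to a double-bonded chain carbon. Going by the values given here, no measured compound carries the 2,4-dimethoxyphenyl group, so the nearest guide is compound 1, whose 3,4,5-trimethoxyphenyl group is also methoxy-bearing. Two steps bear on the change, both modest and both away from compound 1: the one to compound 3 given above and a 2.4-fold higher number from compound 1 to compound 2 (0.38 log units; beyond the scatter). The swap of fluoro for ethyl made no difference beyond the scatter, which suggests that compound 4 might recover part of the gap to compound 1, though not necessarily all of it. A small move toward lower numbers is therefore expected in this assay, no larger than the measured steps.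

The expected change is a 1.6-fold lower number from compound 3 to compound 4 (0.20 log units; within the scatter), and it may not clear the scatter. For compound 4 the estimated value is 400 nM, with an expected range of 180 nM to 900 nM.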

Compound 4, concentration for 50% growth inhibition: 650 nM
Compound 4: the middle estimate sits 1.6-fold (0.21 log units) below what was measured, and the stated range covers the measured number.
By their numbers in this assay, from the lowest: compound 1; then compounds 2, 3 and 4 (each within the scatter of the next).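

In this assay, the methoxy groups of the 2,4-dimethoxyphenyl ring do not by themselves carry a compound toward the low number of compound 1: a 1.0-fold higher number from compound 3 to compound 4 (0.01 log units; within the scatter) and a 1.2-fold higher number from compound 2 to compound 4 (0.07 log units; within the scatter) both lie within the scatter, so this group stands level with 4-ethylphenyl and 4-fluorophenyl, three quite different aryl groups at this place giving the same reading. Going by these compounds alone, only the 3,4,5-trimethoxyphenyl group stays apart, with a 2.8-fold higher number from compound 1 to compound 4 (0.45 log units; beyond the scatter), a modest step but one beyond the scatter, which shows that on this double-bonded chain carbon bound to a double-bonded chain carbon the mere presence of methoxy groups does not decide the outcome, and that compound 1 is the one member set off from the rest. Nothing in the information at hand accounts for this separation.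

With only these two methoxy-bearing aryl groups to compare, the compounds shown cannot say whether the number of methoxy groups or their placing on the ring sets compound 1 apart. They also leave open how a plain phenyl group, or a phenyl group carrying an amine or a carboxylic acid, would stand at this place.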